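Swapping a sulfonamide arm for a bromophenyl ring

The source may report more compounds than this note shows. Statements on the series, on what has been measured and on what is new or still open speak of the compounds shown alone.

Among the compounds with values here, compound 1, `O=C1O[C@H]([C@@H](O)Cn2cc(CNS(=O)(=O)c3ccc(F)cc3)nn2)C(OCc2ccccc2)=C1OCc1ccccc1`, is the lower of the two numbers so far in a functional assay on CFPAC-1 cells (Homo sapiens) for antiproliferative activity, read by MTT assay, with a stated time of 72 h; on this read-out higher numbers stand for weaker inhibition and lower numbers for stronger inhibition: compound 1 gives 34700 nM. Its companion compound 2, `O=C1O[C@H]([C@@H](O)Cn2cc(-c3cc(C(F)(F)F)cc(C(F)(F)F)c3)nn2)C(OCc2ccccc2)=C1OCc1ccccc1`, has a bis(trifluoromethyl)phenyl ring attached directly to the five-membered aromatic ring with 3 nitrogen, and in this assay compound 2 gives 66500 nM; the gap between these two values lies within the usual scatter, so neither can be called the more active. The unmeasured compound 3, `O=C1O[C@H]([C@@H](O)Cn2cc(-c3ccc(Br)cc3)nn2)C(OCc2ccccc2)=C1OCc1ccccc1`, follows from compound 1 by one change: 4-bromophenyl in place of (((4-fluorophenyl)sulfonyl)amino)methyl on an aromatic carbon. Like compound 2, the new compound carries a single aromatic ring directly on the shared core. Since compound 2 gives 66500 nM, the expected step in this assay from compound 1 is a 1.4-fold higher number from compound 1 to compound 3 (0.16 log units; within the scatter), a modest move toward a higher number that may not exceed the scatter. The estimate for compound 3 in this assay is therefore 50000 nM, with a plausible range from 20000 nM to 120000 nM.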

Compound 3, half-maximal inhibitory concentration: 5830 nM
Compound 3: the middle estimate sits 8.6-fold (0.93 log units) above what was measured; measured number outside the range, below it.
By their numbers in this assay, from the lowest: compound 3; then compounds 1 and 2 (each within the scatter of the next).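

In this assay, 4-bromophenyl in place of the sulfonamide arm gives a 6.0-fold lower number from compound 1 to compound 3 (0.77 log units; beyond the scatter), so this aromatic carbon does not need the (((4-fluorophenyl)sulfonyl)amino)methyl group, with its hydrogen-bond donor and acceptors, for activity against these cells. A single aromatic ring on this carbon is not enough on its own: compound 2 also has one and gives 66500 nM, whereas compound 3 gives 5830 nM, so the groups on that ring matter in this pair. Nothing measured here explains why the number falls.

Going by these compounds, what remains open is whether the bromine itself counts or whether any similar ring would do. A plain phenyl ring, or a 4-chlorophenyl or 4-aminophenyl ring, at the same place would help separate these possibilities.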